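Compound 3 to compound 4: cyclohexyl gives way to oxan-4-yl

This account rests on a few compounds, and the source may have more. Where it says the series, first, only, none or still open, it means among the compounds named here.

In a physicochemical assay for lipophilicity, read by HPLC, measured as chromatographic lipophilicity, at pH 7.4 (a higher number here means a more lipophilic compound, a lower number a more polar compound), compound 3 (`O=C(C1CCCCC1)N1N=CCC1c1ccccc1`) gives 5.9 and stands highest of the three measured compounds. Compound 1 (`CC(C)C(=O)N1N=CCC1c1ccccc1`) gives 4.4 and compound 2 (`CC(C)(CO)C(=O)N1N=CCC1c1ccccc1`) gives 3.4 in this assay and both lie lower, beyond the scatter.

The unmeasured compound 4 (`O=C(C1CCOCC1)N1N=CCC1c1ccccc1`) differs from compound 3 by one change: oxan-4-yl in place of cyclohexyl on a carbonyl carbon. Within the data shown here, no measured pair makes this exact swap, so the evidence is indirect.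

The step of a number 1.50 log units higher from compound 1 to compound 3 (beyond the scatter) is large and comes with cyclohexyl in place of isopropyl on a carbonyl carbon. The step of a number 2.50 log units higher from compound 2 to compound 3 (beyond the scatter) is also large and spans the same carbonyl substituent. The nearest guide is compound 2, whose step a number 1.00 log units lower from compound 1 to compound 2 (beyond the scatter) is modest and comes with hydroxymethyl in place of hydrogen. That group is not oxan-4-yl, so the guide is only approximate.

A downward step beyond the scatter, modest to large in size, is therefore expected in this assay for this swap. The estimate means a step of a number 1.60 log units lower from compound 3 to compound 4 (beyond the scatter) as expected here. For compound 4 the estimated value is 4.3 with an expected range from 3.7 to 4.8 for now.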

Compound 4, distribution coefficient: 3.1
For compound 4 the middle estimate is 1.20 log units above the measured one, and the stated range ends above it.
By their numbers in this assay, from the lowest: compounds 4 and 2 (each within the scatter of the next); then compound 1; then compound 3.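

On the carbonyl carbon whose other neighbour is the amide-type nitrogen in a ring, this assay responds strongly to one atom within a six-membered ring: oxan-4-yl in place of cyclohexyl gives a large change (a number 2.80 log units lower from compound 3 to compound 4 (beyond the scatter)), in the same large class as the change from the earlier pair (a number 2.50 log units higher from compound 2 to compound 3 (beyond the scatter)). A six-membered ring at this position therefore does not by itself keep the number above that of the isopropyl compound: cyclohexyl stood higher, whereas oxan-4-yl does not (a number 1.30 log units lower from compound 1 to compound 4 (beyond the scatter)). Two differently built oxygen-bearing groups, oxan-4-yl and 1-(hydroxymethyl)-1-methylethyl, also cannot be told apart at this position (a number 0.30 log units lower from compound 2 to compound 4 (within the scatter)), so the shape of the substituent does not separate them here.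

Nothing in the data on hand bears on the cause of these steps.

Still open, as far as these compounds go, is whether a ring amine such as piperidin-4-yl, or a carboxylic acid on the cyclohexyl ring, would sit at the level of compound 2 and compound 4 or somewhere else entirely.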